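The source may report more compounds than this note shows. Statements on the series, on what has been measured and on what is new or still open speak of the compounds shown alone.

Measured compounds:
compound 1 `Nc1cc(N)c2nc(-c3ccccc3)c(Oc3ccc(Cl)c(Cl)c3)nc2c1` — < 100000 nM in a functional assay on PC-3 cells (Homo sapiens) for inhibition, read by sulforhodamine B assay, with a stated time of 48 h; on this read-out higher numbers stand for lower toxicity in this test and lower numbers for higher toxicity in this test
compound 2 `Nc1cc(N)c2nc(-c3ccccc3)c(NCc3ccc(Cl)c(Cl)c3)nc2c1` — 19100 nM in this assay
compound 3 `CCOC(=O)[C@H](CCC(=O)O)NC(=O)c1ccc(Sc2nc3cc(N)cc(N)c3nc2-c2ccccc2)cc1` — < 100000 nM in this assay

The series shares one core, shown in the structure of compound 1. In this assay compound 1 gives < 100000 nM, which is a limit of the assay and not a number. Compound 3 also sits at a limit in this assay, with < 100000 nM. Only compound 2, at 19100 nM in this assay, gives a number. Compound 1 therefore cannot be placed against compound 2 with any precision. Within the data shown here, the one piece of evidence on where these values sit is the limit of < 100000 nM in this assay, at which 2 of the 3 values shown sit.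

Compound 4 `Nc1cc(N)c2nc(-c3ccccc3)c(Sc3ccc(F)cc3)nc2c1` is not yet measured. The change from compound 1 is (4-fluorophenyl)sulfanyl in place of 3,4-dichlorophenoxy on an aromatic carbon, on an aromatic carbon of the core, next to the ring nitrogen and ortho to a phenyl group. Among the measured compounds shown here, because compound 1 gives only < 100000 nM, no measured step bounds this change; the expectation is a step toward higher toxicity, modest in size, or none beyond the scatter, as a step that the limit leaves unreadable from compound 1 to compound 4. Compound 4 is therefore estimated at 35000 nM in this assay, with a range from 9000 nM to 100000 nM.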

Compound 4, concentration lethal to 50% of the cells: < 100000 nM
Compound 4 ended at the assay's limit (the forecaster's own chance of this, stated with the estimate: 40%); the middle value does not contradict the limit.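

In this assay compound 4 gives < 100000 nM, which is a limit and not a number. Compound 1 also sits at a limit, so no step from compound 1 to compound 4 can be read: the limit of < 100000 nM in this assay, at which 3 of the 4 values shown sit.

Left open is how (4-fluorophenyl)sulfanyl and 3,4-dichlorophenoxy on the shared core compare in toxicity in this test.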